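Replacing vinyl on the carbonyl of compound 2

The source may hold more compounds than are shown below. What is called first, only, known or untested is meant among the compounds shown, and "the series" means these compounds.

- Compound 1 `C=CC(=O)Nc1cccc(Oc2nc(Nc3cccc(OC)c3)nc3c2CSCC3)c1` gives 10100 nM
- Compound 2 `C=CC(=O)Nc1cccc(Oc2nc(Nc3cccc(C#N)c3)nc3c2CSCC3)c1` gives 6860 nM

Both values come from a functional assay on A549 cells (Homo sapiens) for antiproliferative activity, read by MTT assay, with a stated time of 72 h; on this read-out lower numbers stand for stronger inhibition and higher numbers for weaker inhibition. Compound 2 at 6860 nM has one neighbour on these numbers: a 1.5-fold lower number from compound 1 to compound 2 (0.17 log units; within the scatter). Compound 3 `CC(C)/C=C/C(=O)Nc1cccc(Oc2nc(Nc3cccc(C#N)c3)nc3c2CSCC3)c1` differs from compound 2 by 3-methylbut-1-en-1-yl in place of vinyl on a carbonyl carbon, with 3-methylbut-1-en-1-yl in place of vinyl on a carbonyl carbon. Among the measured compounds shown here, the one measured step, cyano in place of methoxy, lies elsewhere and stayed within the scatter, so no measured step sizes this change. A modest rise in the number is expected, though without direct support. The expected change is a 1.6-fold higher number from compound 2 to compound 3 (0.21 log units; within the scatter). The estimate for compound 3 is 11000 nM, with a range of 4500 nM to 28000 nM.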

Compound 3, half-maximal inhibitory concentration: 35900 nM
Beside the measured number, compound 3's estimate is 3.3-fold (0.51 log units) below it, and the stated range ends below it.
By their numbers in this assay, from the lowest: compounds 2 and 1 (each within the scatter of the next); then compound 3.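

Among the compounds shown here, this is the only step that lies beyond the scatter: in this assay, 3-methylbut-1-en-1-yl in place of vinyl on the carbonyl carbon gives a 5.2-fold higher number from compound 2 to compound 3 (0.72 log units; beyond the scatter), so inhibition weakens. The number therefore responds to the group at this position, whereas the cyano for methoxy change elsewhere stayed within the scatter. No measurement at hand bears on why the number rises.

Open, going by these compounds, is whether the rise follows the longer chain or its branching. A prop-1-en-1-yl or an ethyl group on the same carbonyl carbon would help separate the two.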